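This account rests on a few compounds, and the source may have more. Where it says the series, first, only, none or still open, it means among the compounds named here.

In an ADME assay on HEK293 cells (Homo sapiens) for cytotoxicity, with a stated time of 6 h (a lower number here means that less compound is tolerated, a higher number that more compound is tolerated), compound 1 (`CCCCNc1nc(N)nc2cccc(C)c12`) reads > 25000 nM as a limit of the assay and not a number. Compound 2 (`CCCCNc1nc(N)nc2cccc(OCc3ccccn3)c12`) reads > 25000 nM in this assay and that too is only a limit. Its exact place on the scale is therefore unknown, and the evidence so far is short (the limit of > 25000 nM in this assay, at which 2 of the 2 values shown sit). Compound 3 (`CCCCNc1nc(N)nc2cccc(OCc3cccnc3)c12`) differs from compound 2 by one swap: pyridin-3-yl in place of pyridin-2-yl on a saturated chain carbon bound to an oxygen on an aromatic ring. Among the compounds with values here, the only measured step involves a different change (a step that the two limits leave unreadable from compound 1 to compound 2) and gives no size to carry over. No change beyond the usual scatter is expected in this assay, and the estimated step is small (a step that the limit leaves unreadable from compound 2 to compound 3) with another limit the likeliest reading. For compound 3 the estimated half-maximal cytotoxic concentration is 30000 nM with an expected range from 15000 nM to 60000 nM as the likely span.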

Compound 3, half-maximal cytotoxic concentration: > 25000 nM
Compound 3: only a limit was reported; the forecaster's own chance of this, stated with the estimate: 85%; the middle value is on the limit's open side.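

Within the data shown here, no step between compound 1, compound 2 and compound 3 can be read in this assay, because each result is only a limit of the assay and not a number: the limit of > 25000 nM in this assay, at which 3 of the 3 values shown sit.

The compounds shown leave open where each one truly lies on the scale, and whether pyridin-3-yl in place of pyridin-2-yl changes the reading at all.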